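The source may hold more compounds than are shown below. What is called first, only, known or untested is meant among the compounds shown, and "the series" means these compounds.

In a functional assay on A549 cells (Homo sapiens), read by MTT assay, with a stated time of 72 h (a lower number here means a stronger inhibitor, a higher number a weaker inhibitor), compound 1 `Nc1nc(N)c2c(-c3ccsc3)cn([C@@H]3O[C@H](CO)[C@@H](O)[C@H]3O)c2n1` gives > 100000 nM, which is a limit and not a number. Compound 2 `COc1nc(N)nc2c1c(-c1cccs1)cn2[C@@H]1O[C@H](CO)[C@@H](O)[C@H]1O` also stands only at a limit, > 20000 nM, so neither compound has a measured potency. Compound 3 `COc1nc(N)nc2c1c(-c1ccsc1)cn2[C@@H]1O[C@H](CO)[C@@H](O)[C@H]1O` has thiophen-3-yl in place of thiophen-2-yl on an aromatic carbon of the shared core: thiophen-3-yl in place of thiophen-2-yl on an aromatic carbon. Among the measured compounds shown here, no measured step tests this exchange, and the two groups count alike, so no change beyond the scatter is expected. The expected change is a step that the limit leaves unreadable from compound 2 to compound 3. For compound 3 the estimated value is 25000 nM, with an expected range of 6000 nM to 100000 nM.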

Compound 3, half-maximal inhibitory concentration: > 100000 nM
Compound 3 ended at the assay's limit; the forecaster's own chance of this, stated with the estimate: 70%; at least 4.0-fold (0.60 log units) between middle value and limit.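

Compound 1, compound 2 and compound 3 all stand at limits, so neither step to compound 3 can be read. The compounds shown leave open whether either exchange alters potency in this assay.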